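Trimming a side chain to chloro on a quinoline-type core

This account rests on a few compounds, and the source may have more. Where it says the series, first, only, none or still open, it means among the compounds named here.

Measured compounds in a functional assay on SW707 cells (Homo sapiens) for antiproliferative activity, with a stated time of 72 h; on this read-out higher numbers stand for weaker inhibition and lower numbers for stronger inhibition:
compound 1, `CSc1cnc2ccccc2c1[Se]CC#CCOC(=O)c1ccc(C(=O)O)cc1`, 3.7 ug/mL
compound 2, `OCC#CCSc1cnc2ccccc2c1SCC#CCCl`, 19.8 ug/mL
compound 3, `O=C(/C=C/c1ccccc1)OCC#CCSc1cnc2ccccc2c1Cl`, 48.8 ug/mL

Among the three numbers, compound 2 holds the second highest, which here means the second weakest inhibition. Its nearest neighbour is compound 3, whose number is higher by a margin beyond the scatter, while compound 1 sits furthest away with a lower number, again beyond the scatter. Compound 2 is thus neither the strongest nor the weakest of the set.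

The unmeasured compound 4, `OCC#CCSc1cnc2ccccc2c1Cl`, differs from compound 2 in a single place: one chlorine atom in place of a group of 6 heavy atoms (4 carbon, 1 sulfur, 1 chlorine; no ring), on an aromatic carbon. The change sits on an aromatic carbon of a six-membered aromatic ring with one nitrogen, ortho to a fused ring and opposite the ring nitrogen.

Within the data shown here, no step between measured compounds matches this change, so the expectation rests on the shared chloro of compound 3 and the spread of the three values. Compound 3 carries chloro at this position and gives the highest number, so the expected step in this assay from compound 2 to compound 4 is a modest rise, a 1.5-fold higher number from compound 2 to compound 4 (0.18 log units; within the scatter), possibly within the scatter. Compound 4 is estimated at 30 ug/mL, with a range from 12 ug/mL to 75 ug/mL.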

Compound 4, concentration for 50% inhibition: 6.2 ug/mL
For compound 4 the middle estimate is 4.8-fold (0.68 log units) above the measured one; measured number outside the range, below it.
By their numbers in this assay, from the lowest: compounds 1 and 4 (each within the scatter of the next); then compound 2; then compound 3.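

In this assay, the group of 6 heavy atoms on this aromatic carbon, opposite the ring nitrogen, now has its first readable change: a 3.2-fold lower number from compound 2 to compound 4 (0.50 log units; beyond the scatter) when chloro enters in its place. In this pair, then, inhibition of the cells does not depend on the larger group with its triple bond, and the much smaller chloro gives the lower number. The result also separates chloro from the high number seen earlier, since compound 3 gives 48.8 ug/mL and compound 4 gives 6.2 ug/mL with the same chloro on this carbon, so their printed gap has to come from the one place where they differ. Nothing shown gives a reason for the step at this position.

From the compounds shown here alone, whether the gain belongs to chloro itself or simply to the loss of the larger group remains open, and an amine, a methoxy group or plain hydrogen on this carbon would help to separate the two. Going by these compounds, it is also open whether a shorter chain on this carbon would give a number closer to compound 2 or to compound 4, and whether the step holds on other cells.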